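A few compounds are considered here, and "the series" means these few. Any claim that something is new, unique, unknown or untested is made for them only; others in the source may bear on it.

Three compounds share one core. Compound 1 `CC(=O)c1cccc(Nc2nc(-c3sc(NC(=O)c4ccc(I)cc4)nc3C)cs2)c1` and compound 2 `CC(=O)c1cccc(Nc2nc(-c3sc(NC(=O)c4ccc(C)cc4)nc3C)cs2)c1` carry aryl amides; in an ADME assay on RD cells (Homo sapiens) for cytotoxicity, read by microscopy (on this read-out lower numbers stand for higher toxicity in this test and higher numbers for lower toxicity in this test), compound 1 gives "not determined" (no result reported) and compound 2 gives "not determined" (no result reported), so for neither was a result reported. Among the measured compounds shown here, compound 3 `CC(=O)c1cccc(Nc2nc(-c3sc(NC(=O)OC(C)(C)C)nc3C)cs2)c1` is therefore the only one with a number: in this assay compound 3 gives 101000 nM, and it stands alone, with no second value to place it against.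

Compound 4 `CC(=O)c1cccc(Nc2nc(-c3sc(NC(=O)C(F)(F)F)nc3C)cs2)c1` differs from compound 3 in a single spot: trifluoromethyl in place of tert-butoxy on a carbonyl carbon. For the measured compounds named here, no measured pair shows this change, so no step can be read off. The expected step from compound 3 to compound 4 is a 1.7-fold lower number from compound 3 to compound 4 (0.23 log units; within the scatter), a small move toward higher toxicity that may well lie within the scatter. Compound 4 is thus expected to give about 60000 nM, in the range 20000 nM to 150000 nM.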

Compound 4, half-maximal cytotoxic concentration: 30100 nM
Compound 4: middle estimate off by 2.0-fold (0.30 log units), on the high side; the range from low to high includes it.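

On the carbonyl carbon whose other neighbour is the amide-type nitrogen, trifluoromethyl in place of tert-butoxy gives a 3.4-fold lower number from compound 3 to compound 4 (0.53 log units; beyond the scatter) in this assay, a modest move toward higher toxicity in this test. Among the compounds shown here, compound 3 alone could not show that this position responds to a change at all; this is the first measured step there. Nothing at hand accounts for the step.

For the compounds shown here, no step to compound 1 or compound 2 can be read. From the compounds shown here alone, how a longer chain or an amine on this carbonyl carbon would read remains open.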